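This account rests on a few compounds, and the source may have more. Where it says the series, first, only, none or still open, it means among the compounds named here.

Compound 2 `CCCCNC(=C\C(=O)/C=C/c1ccc(O)c(OC)c1)/C=C/c1ccc(O)c(OC)c1` belongs to a small pair of curcumin-like enamines that differ only in the chain on the amine nitrogen. In a functional assay for inhibition, read by spectrophotometry, with a stated time of 30 min, tested at 1 uM (on this read-out lower numbers stand for less inhibition and higher numbers for more inhibition at the one concentration tested (going by the name of the read-out)), compound 2 gives 0.08%, and its companion compound 1 `CCCNC(=C\C(=O)/C=C/c1ccc(O)c(OC)c1)/C=C/c1ccc(O)c(OC)c1` gives 0.1% in this assay; the two values stand within the usual scatter of each other, so the inhibition in this assay is level between the two and neither number can be called the higher or the lower of the pair. Among the compounds with values here, the one measured step, a number 0 percentage points lower from compound 1 to compound 2 (within the scatter), brought no change beyond the scatter.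

Compound 3 `COc1cc(/C=C/C(=O)/C=C(/C=C/c2ccc(O)c(OC)c2)NCC(C)C)ccc1O` is not yet measured in this assay. It differs from compound 2 by isopropyl in place of propyl on a saturated chain carbon bound to an amine nitrogen; the two have the same atoms, joined differently, so that butylamino becomes isobutylamino. Within the data shown here, the only step that bears on this, the one from compound 1 to compound 2, also rearranged the chain on the amine nitrogen and moved the read-out by nothing beyond the scatter. Compound 3 is therefore expected to stay at the same low level, with a step of a number 0 percentage points higher from compound 2 to compound 3 (within the scatter) in this assay. The estimate for compound 3 is 0.1%, with a range from 0% to 8%.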

Compound 3, a percentage reported as inhibition, at one concentration (the size of the read-out at that concentration, not a potency): 0.09%
For compound 3 the middle estimate is 0 percentage points above the measured one; the range from low to high includes it.
By their numbers in this assay, from the lowest: compounds 2, 3 and 1 (each within the scatter of the next).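

Within the data shown here, until this result, the only change to the chain on the amine nitrogen had added a carbon to a straight chain. Here the same atoms are joined differently, replacing propyl with isopropyl on a saturated chain carbon bound to an amine nitrogen, and this assay shows a number 0 percentage points higher from compound 2 to compound 3 (within the scatter). Read the other way, as methyl in place of hydrogen on a saturated chain carbon bound to two saturated chain carbons, the branch gives a number 0 percentage points lower from compound 1 to compound 3 (within the scatter), so among these three compounds neither branching nor this added methyl moves the read-out beyond the scatter, and no measurement at hand offers an account of that level reading.

Going by these compounds, all three compounds carry short saturated chains on the amine nitrogen, so it remains open whether a longer chain such as octyl, a benzyl group or a chain ending in a carboxylic acid would read any differently in this assay. On these data alone, it also remains open whether these three compounds would stay level with each other at a concentration other than the one tested.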